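The source may report more compounds than this note shows. Statements on the series, on what has been measured and on what is new or still open speak of the compounds shown alone.

Measured so far:
Compound 1 `CCCCc1cc2c(=O)c(-c3ccc(C(F)(F)F)cc3)c(C)[nH]c2cc1OCCOc1ccccc1`: 20000 nM
Compound 2 `CCCCc1cc2c(=O)c(-c3cccc(Oc4ccc(F)cc4)c3)c(C)[nH]c2cc1OCCOc1ccccc1`: 19000 nM

In an ADME assay on J774 cells (Mus musculus) for antiproliferative activity, with a stated time of 72 h (a lower number here means that less compound is needed, a higher number that more compound is needed for the effect), compound 1 gives 20000 nM and compound 2 gives 19000 nM. Within the data shown here, these two values lie within the usual scatter of each other, so compound 1 stands level with the only other compound measured.

Compound 3 `CCCCc1cc2c(=O)c(-c3c(C)noc3C)c(C)[nH]c2cc1OCCOc1ccccc1` has not yet been measured. It keeps the core of compound 1 but carries 3,5-dimethyl-1,2-oxazol-4-yl in place of 4-(trifluoromethyl)phenyl on an aromatic carbon. Among the measured compounds shown here, no measured pair shows this change directly, so any forecast rests on thin evidence. For the measured compounds named here, the only guide is that compound 1 at 20000 nM and compound 2 at 19000 nM show no spread beyond the scatter. No large move in this assay is therefore expected, and any shift should stay within the scatter, leaning slightly towards more compound being needed. The estimated step is a 1.3-fold higher number from compound 1 to compound 3 (0.10 log units; within the scatter). For compound 3 the expected value is 25000 nM, with an estimated range of 10000 nM to 60000 nM.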

Compound 3, half-maximal effective concentration: 22000 nM
The estimate for compound 3 lay 1.1-fold (0.06 log units) above the measured number, and the stated range covers the measured number.
By their numbers in this assay, from the lowest: compounds 2, 1 and 3 (each within the scatter of the next).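

In this assay, among these compounds, 3,5-dimethyl-1,2-oxazol-4-yl in place of 4-(trifluoromethyl)phenyl on this aromatic carbon gives a 1.1-fold higher number from compound 1 to compound 3 (0.04 log units; within the scatter), the first direct reading of a replacement at this position, and the two numbers cannot be told apart. The replacement exchanges a six-membered aromatic ring of carbon only for a five-membered aromatic ring with 2 hetero atoms, goes from 10 heavy atoms to 7, and goes from 0 hydrogen-bond acceptors to 2, yet the result stays within the scatter. No available measurement offers an explanation for this result, so it stands as an observation only.

The compounds shown carry only aromatic rings at this position, so it remains open whether an amine or a carboxylic acid on a short chain there would give a number outside the scatter of compound 1. Also open, as far as these compounds go, is whether a longer chain in place of the methyl group ortho to this position would give a different number in this assay.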